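The compounds below may be only part of what the source reports. "The series", "measured", "known", "first", "only" and "open" are said of these compounds alone.

Of the compounds shown here, three sharing one core have been measured in a physicochemical assay for solubility, with a stated time of 18 h, at pH 7.4; on this read-out higher numbers stand for higher solubility and lower numbers for lower solubility. Compound 1 `COc1ccccc1Oc1ccc2c(NCCCNCc3ccco3)ccnc2c1` gives 14500 nM, compound 2 `CC(C)Cc1ccc2c(NCCCNCc3ccco3)ccnc2c1` gives 4200 nM, and compound 3 `c1ccc(-c2ccc3c(NCCCNCc4ccco4)ccnc3c2)cc1` gives 32000 nM. Compound 2 stands lowest of the three: the steps run a 3.5-fold lower number from compound 1 to compound 2 (0.54 log units; beyond the scatter) and a 7.6-fold higher number from compound 2 to compound 3 (0.88 log units; beyond the scatter), while between the other two the step is a 2.2-fold higher number from compound 1 to compound 3 (0.34 log units; beyond the scatter). Every one of these steps changes the group on an aromatic carbon of the core.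

Compound 4 `COc1ccc(F)cc1CNCCCNc1ccnc2cc(CC(C)C)ccc12` keeps the isobutyl of compound 2 and alters a different place: 5-fluoro-2-methoxyphenyl in place of furan-2-yl on a saturated chain carbon bound to an amine nitrogen. Within the data shown here, no measured step touches this chain position, so none of the three steps bears directly on it. What the measured steps do show is that exchanging groups on this core has moved this assay by modest amounts only. The value of compound 4 in this assay is therefore expected to sit near that of compound 2, with the step of a 1.4-fold lower number from compound 2 to compound 4 (0.15 log units; within the scatter) expected to be small. The estimate for compound 4 is 3000 nM, ranging from 1000 nM to 9000 nM.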

Compound 4, solubility: 4200 nM
Compound 4: middle estimate off by 1.4-fold (0.15 log units), on the low side; measured number inside the range.
By their numbers in this assay, from the lowest: compounds 2 and 4 (each within the scatter of the next); then compound 1; then compound 3.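

Among these compounds, the chain position, which no earlier step touched, now has a measured step of its own: in this assay, 5-fluoro-2-methoxyphenyl in place of furan-2-yl gives no change at the digits printed from compound 2 to compound 4 (within the scatter), whereas the three earlier steps on an aromatic carbon of the core all lie beyond the scatter. With isobutyl on the core, then, a five-membered aromatic ring with one hetero atom gives way here to a six-membered aromatic ring of carbon only, with more heavy atoms, and the number stays within the scatter. No measurement shown offers a reason for this result.

As far as these compounds go, whether the swap behaves the same way with phenyl or 2-methoxyphenoxy on the core remains open. So does the reading in this assay with a carboxylic acid, a second amine or a longer chain at this chain carbon.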